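The source may hold more compounds than are shown below. What is called first, only, known or untested is meant among the compounds shown, and "the series" means these compounds.

Compound 1 `COc1ccc([C@H](C(=O)N(C)C)N2C(=O)[C@@H](C3Cc4ccccc4C3)NC(=O)[C@H]2CC(C)C)cn1` gives 2.7 in a physicochemical assay for lipophilicity, read by HPLC; a lower number here means a more polar compound, a higher number a more lipophilic compound; compound 2 `CC(C)C[C@@H]1C(=O)N[C@H](C2Cc3ccccc3C2)C(=O)N1[C@@H](C(=O)N(C)C)c1ccc(N(C)C)nc1` gives 2.6; compound 3 `Cc1ccc([C@H](C(=O)N(C)C)N2C(=O)[C@@H](C3Cc4ccccc4C3)NC(=O)[C@H]2CC(C)C)cn1` gives 2.1.

Compound 3 stands lowest of the three in this assay: the steps of a number 0.60 log units lower from compound 1 to compound 3 (beyond the scatter) and a number 0.50 log units lower from compound 2 to compound 3 (beyond the scatter) both lie beyond the scatter, while a number 0.10 log units lower from compound 1 to compound 2 (within the scatter) does not. Compound 4 `CC(C)C[C@@H]1C(=O)N[C@H](C2Cc3ccccc3C2)C(=O)N1[C@@H](C(=O)N(C)C)c1ccc(O)nc1` differs from compound 3 in one place: hydroxy in place of methyl on an aromatic carbon. Among the compounds with values here, no measured step involves a hydroxy group, so the earlier steps show only that this aromatic carbon responds to a change of group by modest amounts. The hydroxy group brings a hydrogen-bond donor and acceptor where the methyl had none, so compound 4 is expected to fall further, by a number 0.80 log units lower from compound 3 to compound 4 (beyond the scatter). The estimate for compound 4 is 1.3, in the range 0.7 to 1.9.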

Compound 4, distribution coefficient: 1.3
Estimate against measurement, compound 4: no gap at the digits printed; measured number inside the range.
By their numbers in this assay, from the lowest: compound 4; then compound 3; then compounds 2 and 1 (each within the scatter of the next).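

This aromatic carbon proved able to give large steps in this assay as well as the modest ones seen so far: hydroxy gives a number 0.80 log units lower from compound 3 to compound 4 (beyond the scatter) and a number 1.30 log units lower from compound 2 to compound 4 (beyond the scatter). The change that alters least on paper, hydrogen in place of methyl on the oxygen, gives the largest step of all, a number 1.40 log units lower from compound 1 to compound 4 (beyond the scatter). Nothing measured here accounts for these steps.

As far as these compounds go, how an unsubstituted amine or a carboxylic acid on this carbon would compare with hydroxy remains open. So does whether a longer alkoxy chain would stay level with methoxy.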